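A Chlorine Replaces a Methyl on Compound 1

The source may hold more compounds than are shown below. What is called first, only, known or untested is meant among the compounds shown, and "the series" means these compounds.

Compound 1 `CC(/C=N/Nc1ccc([N+](=O)[O-])cc1)=N\NC(=O)c1ccccc1C` is the reference point here. In a functional assay on cells (Splenocyte, Mus musculus, strain BALB/c) for inhibition, read by scintillation counting and thymidine incorporation, with a stated time of 72 h (a lower number here means a stronger inhibitor, a higher number a weaker inhibitor), compound 1 gives 6000 nM, the highest of the two numbers that were obtained; its nearest neighbour is compound 3 `CC(/C=N/N(C)c1ccc([N+](=O)[O-])cc1)=N\NC(=O)c1cc([N+](=O)[O-])cc([N+](=O)[O-])c1`, which in this assay gives 1110 nM, a lower number that lies beyond the scatter. Compound 2 `CC(/C=N/Nc1ccc([N+](=O)[O-])cc1)=N\NC(=O)c1ccccc1Oc1ccccc1` in this assay gives only a limit, > 12000 nM. Among the compounds with values here, the one measured step that starts from compound 1 is an at least 2.0-fold higher number from compound 1 to compound 2 (0.30 log units; that floor lies within the scatter), and what that step shows is bounded by the limit of > 12000 nM in this assay, at which 1 of the 3 values shown sits. Compound 3 differs from compound 1 in more than one place, so its value serves only as a second point, not as a step.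

The new compound 4 `CC(/C=N/Nc1ccc([N+](=O)[O-])cc1)=N\NC(=O)c1ccc(Cl)cc1` differs from compound 1 by 4-chlorophenyl in place of 2-methylphenyl on a carbonyl carbon. Within the data shown here, the only step bearing on it, the one to compound 2, altered the same group and gave a limit rather than a number, so it sets no direction for a second, smaller exchange. Compound 4 is therefore expected to stay close to compound 1, with a 1.2-fold lower number from compound 1 to compound 4 (0.08 log units; within the scatter) as the estimated step, lying within the scatter. For compound 4 the estimate in this assay is 5000 nM, between 1500 nM and 15000 nM.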

Compound 4, half-maximal inhibitory concentration: 4200 nM
For compound 4 the middle estimate is 1.2-fold (0.08 log units) above the measured one; low and high end bracket the measured number.
By their numbers in this assay, from the lowest: compound 3; then compounds 4 and 1 (each within the scatter of the next). At a limit, above all of these: compound 2.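

The exchange of 2-methylphenyl for 4-chlorophenyl on this carbonyl carbon gives, in this assay, a 1.4-fold lower number from compound 1 to compound 4 (0.15 log units; within the scatter). Within the data shown here, this is the first single exchange at this place that ends in a number rather than a limit, and it shows that compound 1 and compound 4 cannot be told apart although the two groups differ in both substituent and printed position. Compound 2, with the other exchange at this place, still gives only a limit, so its step cannot be read as a size: the limit of > 12000 nM in this assay, at which 1 of the 4 values shown sits.

The compounds shown do not separate the effect of the substituent from that of its place on the ring. Also open, on these data alone, is how an amine or a carboxylic acid in place of the chlorine of compound 4 would read.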